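The source may hold more compounds than are shown below. What is called first, only, known or untested is meant among the compounds shown, and "the series" means these compounds.

Measured compounds in a functional assay on A549 cells (Homo sapiens) for antiproliferative activity, read by CCK-8 assay, with a stated time of 72 h; on this read-out higher numbers stand for weaker inhibition and lower numbers for stronger inhibition:
- compound 1, `Cc1cccc(C(=O)Nc2cccc(-c3oc4cc(-c5ccc(F)cc5)ccc4c(=O)c3O)c2)c1`: 16500 nM
- compound 2, `O=C(Nc1cccc(-c2oc3cc(-c4ccc(F)cc4)ccc3c(=O)c2O)c1)c1ccc(Br)cc1F`: 46100 nM
- compound 3, `COc1cc(OC)cc(C(=O)Nc2cccc(-c3oc4cc(-c5ccc(F)cc5)ccc4c(=O)c3O)c2)c1`: 2390 nM

Compound 3 gives the lowest number of the three; compound 1 sits a 6.9-fold lower number from compound 1 to compound 3 (0.84 log units; beyond the scatter) away from it, compound 2 further still, with a 19-fold lower number from compound 2 to compound 3 (1.29 log units; beyond the scatter). All three share the same core and differ only in the aryl group on the amide carbonyl, so the whole spread seen so far comes from that one aryl group.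

The next compound, compound 4, `Cc1cc(C)cc(C(=O)Nc2cccc(-c3oc4cc(-c5ccc(F)cc5)ccc4c(=O)c3O)c2)c1`, is not yet measured. It differs from compound 3 in a single place: 3,5-dimethylphenyl in place of 3,5-dimethoxyphenyl on a carbonyl carbon. Two methyls thus stand where two methoxy groups stood.

Of the measured steps, the closest comparison is a 6.9-fold lower number from compound 1 to compound 3 (0.84 log units; beyond the scatter), where a 3-methylphenyl amide was exchanged for the 3,5-dimethoxyphenyl amide and the number fell clearly. The other steps, a 2.8-fold higher number from compound 1 to compound 2 (0.45 log units; beyond the scatter) and a 19-fold lower number from compound 2 to compound 3 (1.29 log units; beyond the scatter), show that a halogenated phenyl amide is weaker again. Among the compounds with values here, no measured pair isolates a methoxy-for-methyl swap alone, and no measured compound carries two methyls.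

The exchange in compound 4 removes both acceptor-bearing groups that set compound 3 apart from compound 1, so the number in this assay is expected to move back toward that of compound 1: an estimated step of a 3.3-fold higher number from compound 3 to compound 4 (0.52 log units; beyond the scatter). For compound 4 the estimate in this assay is 8000 nM, with a range from 2500 nM to 25000 nM.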

Compound 4, half-maximal inhibitory concentration: 3740 nM
Beside the measured number, compound 4's estimate is 2.1-fold (0.33 log units) above it; the measured number falls inside the stated range.
By their numbers in this assay, from the lowest: compounds 3 and 4 (each within the scatter of the next); then compound 1; then compound 2.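

In this assay, the exchange of 3,5-dimethoxyphenyl for 3,5-dimethylphenyl on a carbonyl carbon gives a 1.6-fold higher number from compound 3 to compound 4 (0.19 log units; within the scatter), so the oxygen atoms of the two methoxy groups are not required for a number in this range at this position. The methyl in place of hydrogen on an aromatic carbon gives a 4.4-fold lower number from compound 1 to compound 4 (0.64 log units; beyond the scatter), which shows that a step beyond the scatter at this aryl group can be obtained with carbon substituents alone, while the change from a halogenated aryl group gives a 12-fold lower number from compound 2 to compound 4 (1.09 log units; beyond the scatter) and shows that compound 2, which also carries two substituents on this ring, goes against any reading based on substituent number alone. Nothing available here gives a measured reason for any of these steps.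

Still open, going by these compounds, is whether the 3,5-pattern tolerates groups of another kind, such as a dimethylamino group, a carboxylic acid or a longer chain such as ethyl or propyl in place of methyl. Also open, on these data alone, is how a phenyl amide carrying a single methoxy group would compare with compound 1 and compound 3, a comparison that would separate the methoxy-for-methyl swap from the added substituent.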